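The source may hold more compounds than are shown below. What is called first, only, known or untested is meant among the compounds shown, and "the series" means these compounds.

Measured in an assay on membranes from striatum with 5-hydroxytryptamine receptor 4 (Rattus norvegicus) as the target; a lower number here means a stronger inhibitor, a higher number a weaker inhibitor: compound 1 `CCCCN1CCC(CNC(=O)c2cc(Br)cc3[nH]cnc23)CC1` gives 0.646 nM; compound 2 `CCCCN1CCC(CNC(=O)c2cc(Br)c([N+](=O)[O-])c3[nH]cnc23)CC1` gives 47.9 nM; compound 3 `CCCCN1CCC(CNC(=O)c2cc(Cl)c(N)c3[nH]cnc23)CC1` gives 22.4 nM.

Compound 3 stands second highest of these three numbers: its value lies close to that of compound 2 and far from that of compound 1. For the measured compounds named here, the only measured single step, a 74-fold higher number from compound 1 to compound 2 (1.87 log units; beyond the scatter), concerns a nitro group and does not touch the change in question here. Compound 4 `CCCCN1CCC(CNC(=O)c2cc(Br)c(N)c3[nH]cnc23)CC1` differs from compound 3 by bromo in place of chloro on an aromatic carbon, placed ortho to an amino group. Going by the values given here, no measured step swaps one of these two halogens for the other, so in this assay no step beyond the scatter is expected; the estimated step is a 1.2-fold lower number from compound 3 to compound 4 (0.09 log units; within the scatter). Compound 4 is therefore expected to give about 18 nM, between 6 nM and 55 nM.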

Compound 4, inhibition constant: 27.5 nM
Compound 4: the middle estimate sits 1.5-fold (0.18 log units) below what was measured, within the range that was stated.
By their numbers in this assay, from the lowest: compound 1; then compounds 3, 4 and 2 (each within the scatter of the next, the first and the last beyond it).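

In this assay, bromo and chloro on this aromatic carbon, ortho to an amino group, cannot be told apart: a 1.2-fold higher number from compound 3 to compound 4 (0.09 log units; within the scatter). Amino in place of nitro also stays within the scatter, a 1.7-fold lower number from compound 2 to compound 4 (0.24 log units; within the scatter), whereas amino in place of hydrogen gives a large step, a 43-fold higher number from compound 1 to compound 4 (1.63 log units; beyond the scatter). On the neighbouring substituent's carbon, then, the large gap lies between hydrogen and either amino or nitro, not between those two groups.

Nothing available explains these steps. On these data alone, how fluoro or methyl in place of bromo would read remains open, as does a hydroxyl in place of the amino group.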